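The compounds below may be only part of what the source reports. "The series", "measured", "known", "first", "only" and "open" are said of these compounds alone.

Measured so far:
compound 1, `CCC(=O)N1CC2CC(C1)N2`: 190 nM
compound 2, `O=C([C@H]1C[C@@H]1F)N1CC2CC(C1)N2`: 490 nM

In an assay on CHO cells for displacement of a labelled ligand from Neuronal acetylcholine receptor; alpha3/alpha6/beta2/beta3 (Homo sapiens), read by scintillation counting (on this read-out higher numbers stand for weaker inhibition and lower numbers for stronger inhibition), compound 1 has the lowest of the two numbers; its nearest neighbour is compound 2, reached by a 2.6-fold higher number from compound 1 to compound 2 (0.41 log units; beyond the scatter). Compound 3, `C[C@H]1C[C@H]1C(=O)N1CC2CC(C1)N2`, is not yet measured. It differs from compound 1 by 2-methylcyclopropyl in place of ethyl on a carbonyl carbon. Among the compounds with values here, the one step that bears on this, a 2.6-fold higher number from compound 1 to compound 2 (0.41 log units; beyond the scatter), also replaced the ethyl with a substituted cyclopropyl on the same carbonyl carbon and raised the number modestly. A similar modest rise is therefore expected for compound 3, as a 2.1-fold higher number from compound 1 to compound 3 (0.32 log units; beyond the scatter), giving an estimated 400 nM with a range from 150 nM to 1000 nM.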

Compound 3, inhibition constant: 170 nM
Beside the measured number, compound 3's estimate is 2.4-fold (0.37 log units) above it; measured number inside the range.
By their numbers in this assay, from the lowest: compounds 3 and 1 (each within the scatter of the next); then compound 2.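

In this assay, putting 2-methylcyclopropyl in place of ethyl on the carbonyl carbon gives a 1.1-fold lower number from compound 1 to compound 3 (0.05 log units; within the scatter), so this position takes the larger ring-bearing group without a change beyond the scatter. Exchanging 2-fluorocyclopropyl for 2-methylcyclopropyl gives a 2.9-fold lower number from compound 2 to compound 3 (0.46 log units; beyond the scatter), which shows that a cyclopropyl ring here does not by itself bring the higher number seen with compound 2. Nothing available explains this difference between the two groups. The compounds shown leave open how plain cyclopropyl, a longer chain such as butyl, or an amine would fare on this carbonyl carbon. They also leave open how other stereoisomers of 2-methylcyclopropyl would compare.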